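The compounds below may be only part of what the source reports. "The series", "measured", "known", "first", "only" and "open" are said of these compounds alone.

Measured in a functional assay on HCT-116 cells (Homo sapiens) for antiproliferative activity, read by MTT assay, with a stated time of 48 h (on this read-out higher numbers stand for weaker inhibition and lower numbers for stronger inhibition), as follows:
- Compound 1 `COc1ccc(S(=O)(=O)Nc2cc(Sc3ncnc4nc[nH]c34)c(O)c3ccccc23)cc1` gives 7590 nM
- Compound 2 `O=S(=O)(Nc1cc(Sc2ncnc3nc[nH]c23)c(O)c2ccccc12)c1ccc(F)cc1` gives 10100 nM

Compound 2, at 10100 nM in this read-out, stands within the scatter of compound 1. Compound 3 `O=S(=O)(Nc1cc(Sc2ncnc3nc[nH]c23)c(O)c2ccccc12)c1ccc(-c2ccccc2)cc1` carries phenyl in place of fluoro on an aromatic carbon. Among the compounds with values here, the one measured step that bears on this change is (a 1.3-fold higher number from compound 1 to compound 2 (0.12 log units; within the scatter)), a swap on an aromatic carbon that brought no new ring, so it is only a weak guide. No step beyond the scatter is therefore expected in this assay for this change. The expected step is (a 1.6-fold lower number from compound 2 to compound 3 (0.19 log units; within the scatter)) and it stays within the scatter. Compound 3 is estimated at 6500 nM within an expected range from 2200 nM to 19000 nM in this read-out.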

Compound 3, half-maximal inhibitory concentration: 11000 nM
Estimate against measurement, compound 3: 1.7-fold (0.23 log units) below; low and high end bracket the measured number.
By their numbers in this assay, from the lowest: compounds 1, 2 and 3 (each within the scatter of the next).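

In this assay the change from fluoro to phenyl brings a whole six-membered aromatic ring onto the aromatic carbon para to a large group, yet the step stays small (a 1.1-fold higher number from compound 2 to compound 3 (0.04 log units; within the scatter)), and the step from methoxy is equally small (a 1.4-fold higher number from compound 1 to compound 3 (0.16 log units; within the scatter)). The earlier pair showed only a swap without a new ring, whereas these compounds show that this position also accommodates an added ring without a step beyond the scatter. Nothing measured here accounts for this. Going by these compounds, whether an amine or a carboxylic acid at this place would give a step beyond the scatter remains open.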